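A few compounds are considered here, and "the series" means these few. Any claim that something is new, unique, unknown or untested is made for them only; others in the source may bear on it.

Measured so far in a functional assay on HT-29 cells (Homo sapiens) for inhibition, read by sulforhodamine B assay, with a stated time of 48 h; on this read-out lower numbers stand for stronger inhibition of growth and higher numbers for weaker inhibition of growth:
Compound 1 `CN1CCN(CCCOc2cccc3nc(Nc4ccc(Cl)c(C(F)(F)F)c4)ccc23)CC1` gives 1120 nM.
Compound 2 `CC(C)c1ccc(Nc2ccc3c(OCCCN4CCN(C)CC4)cccc3n2)cc1` gives 2160 nM.
Compound 3 `CN1CCN(CCCOc2cccc3nc(Nc4cc(Cl)cc(Cl)c4)ccc23)CC1` gives 1410 nM.

Compound 3 stands second highest of the three numbers; nearest is compound 1, with the step of a 1.3-fold higher number from compound 1 to compound 3 (0.10 log units; within the scatter), furthest is compound 2, with the step of a 1.5-fold lower number from compound 2 to compound 3 (0.19 log units; within the scatter). Compound 4 `CN1CCN(CCCOc2cccc3nc(Nc4cccc(Cl)c4)ccc23)CC1` differs from compound 3 by hydrogen in place of chloro on an aromatic carbon, on an aromatic carbon of a six-membered aromatic ring of carbon only, meta to a chloro group. Within the data shown here, no measured step removes a substituent from this ring; the bearing steps are the swaps of the whole aryl group, a 1.9-fold higher number from compound 1 to compound 2 (0.29 log units; within the scatter), a 1.3-fold higher number from compound 1 to compound 3 (0.10 log units; within the scatter) and a 1.5-fold lower number from compound 2 to compound 3 (0.19 log units; within the scatter), all within the scatter. The step of a 1.2-fold higher number from compound 3 to compound 4 (0.08 log units; within the scatter) is therefore expected to stay within the scatter in this assay. Compound 4 is estimated at 1700 nM, with a range of 800 nM to 3600 nM.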

Compound 4, concentration for 50% growth inhibition: 1500 nM
Beside the measured number, compound 4's estimate is 1.1-fold (0.05 log units) above it, and the stated range covers the measured number.
By their numbers in this assay, from the lowest: compounds 1, 3, 4 and 2 (each within the scatter of the next).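

In this assay, among these compounds, this is the first step that takes a substituent off the ring instead of swapping the whole aryl group, and removing one chloro gives a 1.1-fold higher number from compound 3 to compound 4 (0.03 log units; within the scatter), so the second chloro shows no measurable contribution at this position. The 3-chlorophenyl group also stays unresolved from the other aryl groups, with a 1.4-fold lower number from compound 2 to compound 4 (0.16 log units; within the scatter) and a 1.3-fold higher number from compound 1 to compound 4 (0.13 log units; within the scatter). No available evidence explains this tolerance.

Still open, on these data alone, is whether the remaining chloro matters, which a plain phenyl group would test. An amine or a carboxylic acid on this ring could show whether the position responds to any change beyond the scatter.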